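A few compounds are considered here, and "the series" means these few. Any claim that something is new, unique, unknown or untested is made for them only; others in the source may bear on it.

Measured so far:
- compound 1 `COC(=O)N1CCC(Oc2cc(Oc3cccc(/C=C4\SC(=O)NC4=O)c3)ncn2)CC1`, which in a functional assay on CHO-K1 cells for agonist activity at Glucose-dependent insulinotropic receptor (Homo sapiens), read by cAMP accumulation and immunoassay, with a stated time of 1 h (on this read-out lower numbers stand for smaller maximal responses and higher numbers for larger maximal responses), gives 33.7%
- compound 2 `CC(C)COC(=O)N1CCC(Oc2cc(Oc3cccc(/C=C4\SC(=O)NC4=O)c3)ncn2)CC1`, which in this assay gives 62.4%

Compound 2 stands highest of the two numbers; the nearest is compound 1, separated by the step of a number 28.7 percentage points higher from compound 1 to compound 2 (beyond the scatter), a modest rise beyond the scatter. The change from compound 2 to compound 3 `O=C1NC(=O)/C(=C/c2cccc(Oc3cc(OC4CCN(C(=O)OCc5ccccc5)CC4)ncn3)c2)S1` is phenyl in place of isopropyl on a saturated chain carbon bound to an oxygen next to a carbonyl group. Within the data shown here, the one measured step that bears on it is a number 28.7 percentage points higher from compound 1 to compound 2 (beyond the scatter), where the group on the saturated chain carbon bound to an oxygen next to a carbonyl group went from hydrogen to isopropyl and the largest response rose modestly. Isopropyl to phenyl is a further change at the same place, but no measured pair shows a six-membered aromatic ring there, so the direction rests on that single step alone. Because compound 2 already reaches 62.4% and the step of a number 28.7 percentage points higher from compound 1 to compound 2 (beyond the scatter) was modest, the expected step is a number 7.6 percentage points higher from compound 2 to compound 3 (within the scatter), upward but not beyond what that earlier step showed. Compound 3 is estimated at 70%, with a range from 48% to 92%.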

Compound 3, largest response reached (Emax), in percent of the reference or control that the assay uses: 98.3%
Compound 3: the middle estimate sits 28.3 percentage points below what was measured; measured number above the stated range.
By their numbers in this assay, from the lowest: compound 1; then compound 2; then compound 3.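

In this assay, the place on a saturated chain carbon bound to an oxygen next to a carbonyl group proves able to carry a six-membered aromatic ring of carbon only: phenyl in place of isopropyl gives a number 35.9 percentage points higher from compound 2 to compound 3 (beyond the scatter), a large step where the earlier change from hydrogen to isopropyl was modest. Taken from the smallest group, phenyl in place of hydrogen gives a number 64.6 percentage points higher from compound 1 to compound 3 (beyond the scatter), so the largest response rises in the order hydrogen, isopropyl, phenyl, and none of the three compounds goes against that order, though three compounds make a short series. The second change at this place therefore adds to the first rather than levelling off, and the data at hand offer nothing that accounts for the size of the rise.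

Cyclohexyl at the same place would help separate the aromatic ring from the plain count of carbons, and a pyridine ring or a methoxy group on the phenyl would show how far the ring itself can be altered. A longer chain, such as phenethyl in place of benzyl on the oxygen, leaves open whether the ring's distance from the carbonyl matters as well.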